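Dichlorophenyl for Trifluoromethylphenyl on the Saturated Ring Carbon

The compounds below may be only part of what the source reports. "The series", "measured", "known", "first", "only" and "open" are said of these compounds alone.

Compound 2 `COc1cc(C2=NN(C(C)=O)C(c3ccccc3C(F)(F)F)O2)cc(OC)c1OC` bears an acetyl group on its five-membered ring and a 2-(trifluoromethyl)phenyl on a saturated ring carbon of that ring. Within the data shown here, in a functional assay on PC-3 cells (Homo sapiens) for antiproliferative activity, read by MTT assay, tested at 1 uM (a lower number here means a weaker effect, a higher number a stronger effect of the compound at the concentration tested), compound 2 gives -11%, the lowest of the three numbers measured so far. The nearest of the others is compound 3 `COc1cc(C(=O)N/N=C/c2ccc(Cl)c(Cl)c2)cc(OC)c1OC`, which in this assay gives 13.5%, a number higher than that of compound 2 by more than the scatter of the method. The furthest is compound 1 `COc1cc(C(=O)N/N=C/c2ccccc2C(F)(F)F)cc(OC)c1OC`, which in this assay gives 45%, also well beyond the scatter above compound 2.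

Compound 4 `COc1cc(C2=NN(C(C)=O)C(c3ccc(Cl)c(Cl)c3)O2)cc(OC)c1OC` has not yet been measured. It differs from compound 2 in one place: 3,4-dichlorophenyl in place of 2-(trifluoromethyl)phenyl on a saturated ring carbon. Among the measured compounds shown here, no pair of measured compounds that differ in only one place is available, so the size of this kind of change in this assay is not known from the data. What the numbers do show is that compound 3 gives 13.5% while compound 1 gives 45%, so the dichlorophenyl compound does not stand above the trifluoromethylphenyl compound there.

On that basis compound 4 is expected to stay near compound 2, with a step of a number 6 percentage points higher from compound 2 to compound 4 (within the scatter) that is not expected to exceed the scatter. Compound 4 is therefore estimated at -5%, within a range of -25% to 15%.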

Compound 4, a percentage reported as inhibition, at one concentration (the size of the read-out at that concentration, not a potency): 28.1%
Compound 4: the middle estimate sits 33.1 percentage points below what was measured, and the stated range ends below it.
By their numbers in this assay, from the lowest: compound 2; then compound 3; then compound 4; then compound 1.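

The exchange of 2-(trifluoromethyl)phenyl for 3,4-dichlorophenyl on a saturated ring carbon gives in this assay a step of a number 39.1 percentage points higher from compound 2 to compound 4 (beyond the scatter) and shows that activity at this position depends on which aryl group the ring carbon carries. The same two aryl groups stand in the opposite order in the compounds that lack the acetyl-bearing ring: compound 1, with 2-(trifluoromethyl)phenyl, gives 45% and stands above compound 3, with 3,4-dichlorophenyl, which gives 13.5% in the same assay, so the order seen in one pair cannot be carried over to the other. Nothing at hand accounts for this reversal.

On these data alone, with a single step at this position, it remains open whether the rise follows from the arrival of the two chlorines, from where they sit on the phenyl ring, or from the departure of the trifluoromethyl group. The compounds shown also leave open what an unsubstituted phenyl or a dimethylamino-bearing phenyl would give on this carbon, and what a propanoyl group would give in place of the acetyl group.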